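Thiazole acetic acids: aryl swap toward a fluoropyridyl group

The source may hold more compounds than are shown below. What is called first, only, known or untested is meant among the compounds shown, and "the series" means these compounds.

Measured so far:
compound 1 `O=C(O)Cc1sc(C(c2ccc(F)cc2)c2ccc(F)cc2)nc1-c1ccc(Cl)cc1` — 9.7 nM
compound 2 `O=C(O)Cc1sc(C(c2ccc(F)cc2)c2ccc(F)cc2)nc1-c1ccco1` — 18 nM

Compound 2 `O=C(O)Cc1sc(C(c2ccc(F)cc2)c2ccc(F)cc2)nc1-c1ccco1` shows the highest of the two numbers in an in vitro assay on HEK385-7 cells for displacement of a labelled ligand from prostaglandin D2 receptor 2 (Homo sapiens) (a lower number here means a stronger inhibitor, a higher number a weaker inhibitor), yet its step from compound 1 is small: a 1.9-fold higher number from compound 1 to compound 2 (0.27 log units; within the scatter). Compound 3 `O=C(O)Cc1sc(C(c2ccc(F)cc2)c2ccc(F)cc2)nc1-c1ccnc(F)c1` is not yet measured; it differs from compound 2 by 2-fluoropyridin-4-yl in place of furan-2-yl on an aromatic carbon. Among the measured compounds shown here, only the step from compound 1 to compound 2 bears on this change, and it stayed within the scatter. A six-membered ring enters where a five-membered one leaves; no larger shift than the one seen is expected, the estimated step being a 1.5-fold lower number from compound 2 to compound 3 (0.18 log units; within the scatter). Compound 3 is therefore expected at 12 nM (range 5 nM to 30 nM).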

Compound 3, half-maximal inhibitory concentration: 0.48 nM
Beside the measured number, compound 3's estimate is 25-fold (1.40 log units) above it; the whole stated range lies above it.
By their numbers in this assay, from the lowest: compound 3; then compounds 1 and 2 (each within the scatter of the next).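

In this assay, this aromatic carbon, next to the ring nitrogen, proves far more sensitive than the earlier pair showed: 2-fluoropyridin-4-yl in place of furan-2-yl gives a 38-fold lower number from compound 2 to compound 3 (1.57 log units; beyond the scatter), and in place of 4-chlorophenyl it gives a 20-fold lower number from compound 1 to compound 3 (1.31 log units; beyond the scatter). Since the six-membered 4-chlorophenyl and the five-membered furan-2-yl lie within the scatter of each other, ring size alone does not track with the gain. No available measurement accounts for the gain. The compounds shown leave open whether the ring nitrogen, the fluorine or the two together go with it. Plain pyridin-4-yl and 3-fluorophenyl would separate these.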